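Series notes: ethylamino, methylsulfanyl, butylsulfinyl and methoxy variants

A few compounds are considered here, and "the series" means these few. Any claim that something is new, unique, unknown or untested is made for them only; others in the source may bear on it.

Measured so far in a functional assay (spleen, spleen) for activation, with Mus musculus as the target; a higher number here means that more compound is needed for the effect, a lower number that less compound is needed:
- compound 1 `CCNc1nc(N)c2nc(O)n(Cc3ccccc3)c2n1`: 1 uM
- compound 2 `CSc1nc(N)c2nc(O)n(Cc3ccccc3)c2n1`: 0.1 uM
- compound 3 `CCCC[S+]([O-])c1nc(N)c2nc(O)n(Cc3ccccc3)c2n1`: 0.01 uM

Compound 1 stands at the highest of the three numbers in this assay. Compound 2 lies nearest to it, with a 10-fold lower number from compound 1 to compound 2 (1.00 log units; beyond the scatter); compound 3 lies furthest, with a 100-fold lower number from compound 1 to compound 3 (2.00 log units; beyond the scatter). Between the two other compounds, a 10-fold lower number from compound 2 to compound 3 (1.00 log units; beyond the scatter).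

The next compound, compound 4 `COc1nc(N)c2nc(O)n(Cc3ccccc3)c2n1`, is not yet measured. It differs from compound 1 in one place: methoxy in place of ethylamino on an aromatic carbon.

For the measured compounds named here, of the measured steps, the one from compound 1 to compound 2 bears most directly on this change, as it likewise replaces the ethylamino group on the shared core with a small group of two heavy atoms and gave a modest lowering, a 10-fold lower number from compound 1 to compound 2 (1.00 log units; beyond the scatter). The larger step to compound 3 involves a longer chain and a sulfinyl group and is a weaker guide. A modest lowering is therefore expected here as well, though methoxy is not methylsulfanyl and the size of that step cannot be assumed to carry over in full.

For compound 4 the expected value in this assay is 0.3 uM, with a range from 0.03 uM to 3 uM. This corresponds to an expected step of a 3.3-fold lower number from compound 1 to compound 4 (0.52 log units; beyond the scatter).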

Compound 4, minimum effective concentration: 0.1 uM
For compound 4 the middle estimate is 3.0-fold (0.48 log units) above the measured one; the measured number falls inside the stated range.
By their numbers in this assay, from the lowest: compound 3; then compounds 2 and 4 (each within the scatter of the next); then compound 1.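

In this assay, methoxy on this aromatic carbon gives a 10-fold lower number from compound 1 to compound 4 (1.00 log units; beyond the scatter), and the oxygen-linked group is not separated from the sulfur-linked one, with no change at the digits printed from compound 2 to compound 4 (within the scatter), so the earlier drop seen with methylsulfanyl is not confined to a sulfur-linked group. Here the change also removes the ethylamino group, with its 1 hydrogen-bond donor, for a methoxy group with 0 hydrogen-bond donors, while the butylsulfinyl group stays clear of both small groups, as the step to methoxy shows a 10-fold higher number from compound 3 to compound 4 (1.00 log units; beyond the scatter) in the same assay. No supporting measurement is available to explain these steps.

The compounds shown do not separate the contribution of the butyl chain from that of the sulfinyl group, and butoxy, butylsulfanyl and methylsulfinyl at this position would address that question. Nor do they show whether the ethylamino result reflects the nitrogen link or the ethyl chain, which methylamino or ethoxy on the shared core would help to distinguish.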